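Fluorine on the Pyridine of an Amide mGlu5 Modulator

The compounds below may be only part of what the source reports. "The series", "measured", "known", "first", "only" and "open" are said of these compounds alone.

Compounds measured so far:
- compound 1, `O=C(Nc1ccccn1)c1cc2n(n1)CCCC2`: 364 nM
- compound 2, `N#Cc1ccnc(NC(=O)c2cc3n(n2)CCCC3)c1`: "not active" (no number reported)
- compound 3, `Cc1ccnc(NC(=O)c2cc3n(n2)CCCC3)c1`: "not active" (no number reported)

All three share one core, an amide that links a bicyclic ring system to a pyridine. They were tested in a functional assay on HEK293 cells for negative allosteric modulation of metabotropic glutamate receptor 5 (Rattus norvegicus), read by FLIPR and calcium flux, with a stated time of 170 s; a higher number here means a weaker inhibitor, a lower number a stronger inhibitor. Compound 1 is the only one of the three with a numerical result; in this assay compound 1 gives 364 nM. Compound 2 and compound 3 each carry a substituent on the pyridine, and each is reported as not active, so no number can be set against compound 1 for either of them.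

Compound 4, `O=C(Nc1cccc(F)n1)c1cc2n(n1)CCCC2`, is the next candidate. Its difference from compound 1 is small: fluoro in place of hydrogen on an aromatic carbon.

For the measured compounds named here, no measured pair here differs in a single place, so there is no directly comparable step to lean on. What the data do show is that two substituted pyridines, compound 2 and compound 3, lost measurable activity, while the unsubstituted compound 1 kept it. Fluoro is the smallest possible addition, so a complete loss seems less likely than for those two, but some weakening beyond the scatter is expected. For compound 4 the expected step is a 2.5-fold higher number from compound 1 to compound 4 (0.39 log units; beyond the scatter), giving an estimate of 900 nM with a range from 250 nM to 4000 nM.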

Compound 4, half-maximal inhibitory concentration: 4740 nM
Estimate against measurement, compound 4: 5.3-fold (0.72 log units) below; the measured number lies above the stated range.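

For the compounds shown here, the change from hydrogen to fluoro on the aromatic carbon next to the ring nitrogen gives the first measured step on the pyridine of this series in this assay: a 13-fold higher number from compound 1 to compound 4 (1.11 log units; beyond the scatter). Compound 2 and compound 3 showed only that two other substituted pyridines gave no number, so they could not show how much activity a substituent costs; this step puts a size on that cost and shows that adding a single fluorine atom at this position is enough to produce a large loss, although compound 4 still gives a measurable result. Nothing measured here bears on why one fluorine atom has so large an effect.

Going by these compounds alone, with fluoro as the only group that gives a number on this carbon, it remains open whether a larger halogen such as chlorine, a methoxy group or an amine in the same place would weaken the compound further, less or not at all. From the compounds shown here alone, it is also open whether fluoro on one of the other aromatic carbons of the pyridine would bring a step of similar size.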